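A few compounds are considered here, and "the series" means these few. Any claim that something is new, unique, unknown or untested is made for them only; others in the source may bear on it.

Two members of the series have numbers in a physicochemical assay for permeability, using PAMPA, at pH 7.4; on this read-out higher numbers stand for higher permeability and lower numbers for lower permeability. Compound 1 `CC(C)S(=O)(=O)NC(=O)c1ccc(Nc2nc(NC3(c4ccc(Cl)cc4)CC3)nc(OCC(F)(F)F)n2)cc1` gives 31 nm/s. Compound 2 `O=C(NS(=O)(=O)CCNC(=O)C1CC1)c1ccc(Nc2nc(NC3(c4ccc(Cl)cc4)CC3)nc(OCC(F)(F)F)n2)cc1` gives 1 nm/s, the lowest of the two numbers. Within the data shown here, the one measured step, a 31-fold lower number from compound 1 to compound 2 (1.49 log units; beyond the scatter), is the change on the sulfonyl sulfur, 2-((cyclopropylcarbonyl)amino)ethyl in place of isopropyl.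

Compound 3 `CC(=O)NCCS(=O)(=O)NC(=O)c1ccc(Nc2nc(NC3(c4ccc(Cl)cc4)CC3)nc(OCC(F)(F)F)n2)cc1` is the next compound. It differs from compound 2 in one place: methyl in place of cyclopropyl on a carbonyl carbon. Among the measured compounds shown here, no measured step in this assay touches this change. For the measured compounds named here, the only step on record, a 31-fold lower number from compound 1 to compound 2 (1.49 log units; beyond the scatter), concerns a much larger swap at a different position and does not bear on a methyl replacing a cyclopropyl on the carbonyl carbon. The series therefore gives nothing to separate compound 2 from compound 3, and a step within the scatter of this assay is expected, in no particular direction. Compound 3 is estimated at 1 nm/s in this assay, with a range from 0.3 nm/s to 3 nm/s. The step this estimate means, no change at the digits printed from compound 2 to compound 3 (within the scatter), is expected to stay within the scatter.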

Compound 3, apparent permeability: 7 nm/s
Estimate against measurement, compound 3: 7.0-fold (0.85 log units) below; the whole stated range lies below it.
By their numbers in this assay, from the lowest: compound 2; then compound 3; then compound 1.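

The acyl end of the chain on the sulfonyl sulfur matters in this assay: methyl in place of cyclopropyl on the carbonyl carbon, a change that removes a three-membered ring and leaves the hydrogen-bond donor and acceptor counts of the group at zero, gives a 7.0-fold higher number from compound 2 to compound 3 (0.85 log units; beyond the scatter), so a small edit far out on the chain moves the number beyond the scatter. The acetyl end does not recover the whole of the loss, since 2-acetamidoethyl in place of isopropyl on the sulfonyl sulfur still gives a 4.4-fold lower number from compound 1 to compound 3 (0.65 log units; beyond the scatter), which places compound 3 between the two earlier compounds. No measurement on hand explains either step.

From the compounds shown here alone, two acyl ends make no trend, so it remains open whether a formyl or a pivaloyl group on the same amide-type nitrogen would continue the direction seen from cyclopropylcarbonyl to acetyl. Also open, going by these compounds, is how the number responds when the acetamido group gives way to a free amine, a carboxylic acid or a simple longer alkyl chain on the sulfonyl sulfur.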